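From 4-fluorophenyl to 4-hydroxy-3-methoxyphenyl in the series

This account rests on a few compounds, and the source may have more. Where it says the series, first, only, none or still open, it means among the compounds named here.

In a functional assay on ECa-109 cells (Homo sapiens) for cytotoxicity, read by MTT assay, with a stated time of 72 h (a higher number here means a weaker inhibitor, a lower number a stronger inhibitor), compound 1 (`CC(C)=C1C(=O)N(c2ccc(Cl)cc2)N(c2ccc(Cl)cc2)C1=O`) gives 42100 nM and compound 2 (`O=C1C(=Cc2ccc(F)cc2)C(=O)N(c2ccc(Cl)cc2)N1c1ccc(Cl)cc1`) gives 35600 nM as its value, so compound 2 stands within the scatter of compound 1. Compound 3 (`COc1cc(C=C2C(=O)N(c3ccc(Cl)cc3)N(c3ccc(Cl)cc3)C2=O)cc(OC)c1OC`) gives 10100 nM as its value, a lower number than compound 2 by more than the scatter. Compound 4 (`COc1cc(C=C2C(=O)N(c3ccc(Cl)cc3)N(c3ccc(Cl)cc3)C2=O)ccc1O`) carries 4-hydroxy-3-methoxyphenyl in place of 4-fluorophenyl on a double-bonded chain carbon bound to a double-bonded ring carbon. The expectation leans on the methoxy-bearing compound 3 (10100 nM), which is thin support. A modest step toward a lower number is expected (a 2.2-fold lower number from compound 2 to compound 4 (0.35 log units; beyond the scatter)). For compound 4 the estimate is 16000 nM with an expected range of 6000 nM to 40000 nM in this assay.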

Compound 4, half-maximal inhibitory concentration: 7100 nM
Estimate against measurement, compound 4: 2.3-fold (0.35 log units) above; low and high end bracket the measured number.
By their numbers in this assay, from the lowest: compounds 4 and 3 (each within the scatter of the next); then compounds 2 and 1 (each within the scatter of the next).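

In this assay, for the compounds shown here, the place on a double-bonded chain carbon bound to a double-bonded ring carbon responds to a change of aryl group: 4-hydroxy-3-methoxyphenyl in place of 4-fluorophenyl gives a 5.0-fold lower number from compound 2 to compound 4 (0.70 log units; beyond the scatter) and provides the first single-place step. No measurement at hand gives a reason for this step.

Whether the hydroxy group or the methoxy group alone would account for the step remains open. As far as these compounds go, how an amine or a carboxylic acid on the phenyl ring would read here also remains open.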